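Compound 3 to compound 4: benzyl to phenyl

A few compounds are considered here, and "the series" means these few. Any claim that something is new, unique, unknown or untested is made for them only; others in the source may bear on it.

Values in a functional assay on Ramos cells (Homo sapiens) for antiproliferative activity (a higher number here means a weaker inhibitor, a lower number a stronger inhibitor), for the measured compounds:
- compound 1 `Nc1ncnc2c1c(-c1ccc(C(=O)Nc3ccc(Oc4ccccc4)cc3)cc1)cn2[C@H]1CCN(C[C@@H]2CO2)C1` gives 3630 nM
- compound 2 `Nc1ncnc2c1c(-c1cc3ccccc3o1)cn2[C@H]1CCN(C[C@H]2CO2)C1` gives 1650 nM
- compound 3 `CC(C)(C)c1ccc(COc2ccc(-c3cn([C@H]4CCN(C[C@@H]5CO5)C4)c4ncnc(N)c34)cc2)cc1` gives 4210 nM

Compound 3 (4210 nM) stands within the scatter of compound 1 (3630 nM). Compound 2 (1650 nM) gives a lower number than compound 3, and that gap lies beyond the scatter.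

The next compound to be measured, compound 4 `CC(C)(C)c1ccc(Oc2ccc(-c3cn([C@H]4CCN(C[C@@H]5CO5)C4)c4ncnc(N)c34)cc2)cc1`, differs from compound 3 in one place (4-(tert-butyl)phenyl in place of 4-(tert-butyl)benzyl on an oxygen on an aromatic ring), with 4-(tert-butyl)phenyl in place of 4-(tert-butyl)benzyl on an oxygen on an aromatic ring.

Within the data shown here, the series offers no measured step between compounds that differ in one place, so this change has no direct precedent. Compound 1 and compound 3 carry different groups on the shared core, yet their values stay within the scatter of each other. Compound 2 goes against that picture. The closest reference is therefore compound 3 at 4210 nM, and no shift beyond the scatter is expected in this assay. The expected step is a 1.2-fold lower number from compound 3 to compound 4 (0.08 log units; within the scatter) and stays within the scatter. For compound 4 the estimate is 3500 nM with a wide expected range (1500 nM to 8000 nM).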

Compound 4, half-maximal inhibitory concentration: 11200 nM
The estimate for compound 4 lay 3.2-fold (0.51 log units) below the measured number, and the stated range ends below it.
By their numbers in this assay, from the lowest: compound 2; then compounds 1 and 3 (each within the scatter of the next); then compound 4.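

In this assay, the series now has its first measured step between compounds that differ in one place: (4-(tert-butyl)benzyl)oxy to 4-(tert-butyl)phenoxy gives a 2.7-fold higher number from compound 3 to compound 4 (0.42 log units; beyond the scatter). The number at this position on the aromatic ring therefore responds to a small change in the group on the oxygen, while the six-membered aromatic ring stays and neither group carries a hydrogen-bond donor, acceptor or net charge. No measurement at hand bears on what lies behind this step.

One step cannot show whether the number follows the length of the link between the oxygen and the tert-butyl-bearing ring, and a longer chain such as 4-(tert-butyl)phenethyl on the same oxygen would test this. From the compounds shown here alone, it also remains open whether the step holds when the tert-butyl group is replaced by a carboxylic acid or an amine, or when the oxygen on the aromatic ring gives way to a nitrogen-hydrogen link.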